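The source may report more compounds than this note shows. Statements on the series, on what has been measured and on what is new or still open speak of the compounds shown alone.

Series notes. Compound 1 `COC(=O)C(=N)/C=C(\O)c1ccccc1Cl` in an assay for inhibition of kynurenine 3-monooxygenase (Rattus norvegicus), tested at 10 uM (a higher number here means more inhibition at the concentration tested (going by the name of the read-out), a lower number less inhibition), gives 31%. Compound 3 `COC(=O)C(=N)/C=C(\O)c1cccc(Cl)c1Cl` carries chloro in place of hydrogen on an aromatic carbon on the core of compound 1; in this assay compound 3 gives 33%, so the step of a number 2 percentage points higher from compound 1 to compound 3 (within the scatter) is small. Compound 2 `COC(=O)C(=N)/C=C(\O)c1ccc(Cl)cc1` has the same atoms as compound 1 joined differently; the difference between the two cores is not broken down here. In this assay compound 2 gives 13%, the lowest of the three numbers. Compound 4 `COC(=O)C(=N)/C=C(\O)c1ccc(Cl)c(Cl)c1` is not yet measured; it carries on the core of compound 2 the same change, (chloro in place of hydrogen on an aromatic carbon), with the same surroundings at the place of change as in compound 3. Because the earlier step of a number 2 percentage points higher from compound 1 to compound 3 (within the scatter) lay within the scatter, the step to compound 4 is expected to be of similar size, a number 3 percentage points higher from compound 2 to compound 4 (within the scatter). Compound 4 is therefore estimated to give 16% in this assay, expected to fall between 4% and 30%.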

Compound 4, a percentage reported as inhibition, at one concentration (the size of the read-out at that concentration, not a potency): 37%
Compound 4: middle estimate off by 21 percentage points, on the low side; measured number outside the range, above it.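

In this assay the size of the step for chloro in place of hydrogen on an aromatic carbon does not carry over from one core to the other: the same change on two cores in this assay, a number 2 percentage points higher (within the scatter) from compound 1 to compound 3 and a number 24 percentage points higher (beyond the scatter) from compound 2 to compound 4, 22 percentage points apart, beyond the scatter of two such steps. The larger step, a number 24 percentage points higher from compound 2 to compound 4 (beyond the scatter), therefore cannot be taken as a general gain for this change. This rests on one pair of steps at a single concentration, so it shows that the step size differs between these two cores but neither explains the difference nor gives a rule for other cores.

The compounds shown leave open whether fluoro or methoxy in place of chloro would show the same difference between cores. Going by these compounds, it also remains open how a carboxylic acid in place of the methyl ester would read.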